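The source may hold more compounds than are shown below. What is called first, only, known or untested is meant among the compounds shown, and "the series" means these compounds.

Values measured so far in a physicochemical assay for acid dissociation:
compound 1 `COc1cnc(C[S+]([O-])c2nc3cc(OC(F)F)ccc3[nH]2)c(C)c1OC` gives 8.35
compound 2 `COc1ccnc(C[S+]([O-])c2nc3cc(OCC(F)(F)F)ccc3[nH]2)c1OC` gives 8.52
compound 3 `COc1cnc(C[S+]([O-])c2nc3cc(OCC(F)(F)F)ccc3[nH]2)c(C)c1OC` gives 8.61

Compound 3 (at 8.61) lies within the scatter of both other compounds. Compound 4 `COc1ccnc(C[S+]([O-])c2nc3cc(OCC(F)(F)F)ccc3[nH]2)c1C` carries hydrogen in place of methoxy on an aromatic carbon. Going by the values given here, the only measured step between compounds differing in one place (a number 0.26 log units higher from compound 1 to compound 3 (within the scatter)) is a different change, 2,2,2-trifluoroethyl in place of difluoromethyl on an oxygen on an aromatic ring, and it stays within the scatter. Among the compounds with values here, no measured step removes a methoxy, so this evidence is indirect. A step beyond the scatter is therefore not expected in this assay, and the estimated step is expected to be a number 0.01 log units lower from compound 3 to compound 4 (within the scatter). Compound 4 is estimated at 8.6 (expected range 8.3 to 8.9).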

Compound 4, acid dissociation constant: 8.51
Beside the measured number, compound 4's estimate is 0.09 log units above it; the range from low to high includes it.
By their numbers in this assay, from the lowest: compounds 1, 4, 2 and 3 (each within the scatter of the next).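

At this aromatic carbon, two atoms from the ring nitrogen, hydrogen in place of methoxy gives a number 0.10 log units lower from compound 3 to compound 4 (within the scatter) in this assay, so removing this methoxy leaves the number within the scatter. Methyl in place of methoxy on an aromatic carbon gives a number 0.01 log units lower from compound 2 to compound 4 (within the scatter), so this second exchange on the ring also stays within the scatter, as does the one step known before. No available evidence bears on these results. As far as these compounds go, whether an amine or a chlorine on this aromatic carbon would give a step beyond the scatter remains open.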